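This account rests on a few compounds, and the source may have more. Where it says the series, first, only, none or still open, it means among the compounds named here.

Compound 1 `COc1ccccc1-c1cccc(S(=O)(=O)N2CCC(N3CCC(C)CC3)CC2)c1`: > 5000 nM
Compound 2 `CC(=O)Nc1ccc(S(=O)(=O)N2CCC(N3CCC(C)CC3)CC2)c2ccccc12`: > 10000 nM

Of the compounds shown here, two have been measured in an ADME assay on HCT-116 cells (Homo sapiens) for cytotoxicity, read by CellTiter-Glo, with a stated time of 72 h; a higher number here means a weaker inhibitor, a lower number a stronger inhibitor. Compound 1 gives > 5000 nM, which is a limit of the assay rather than a number. Compound 2 gives > 10000 nM, likewise a limit rather than a number. Compound 1 therefore stands only at a limit, the one given by the limit of > 5000 nM in this assay, at which 1 of the 2 values shown sits, while the other value shown sits at the limit of > 10000 nM in this assay, at which 1 of the 2 values shown sits. The two values show nothing more than that neither compound produced a measurable number within the range of the assay.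

Compound 3 `Cc1ccc(-c2cccc(S(=O)(=O)N3CCC(N4CCC(C)CC4)CC3)c2)cc1` has not yet been measured in this assay. It differs from compound 1 by 4-methylphenyl in place of 2-methoxyphenyl on an aromatic carbon. Going by the values given here, no step between two measured compounds exists to scale this change, and a limit on compound 1 provides no number from which a direction could be read. No movement beyond the usual scatter is expected in this assay. The step that the limit leaves unreadable from compound 1 to compound 3 is expected to be small. Compound 3 is expected to come out near 10000 nM, with a range from 3000 nM to 40000 nM, most likely again as a limit rather than a number.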

Compound 3, half-maximal inhibitory concentration: > 5000 nM
Compound 3 was reported as a limit; the forecaster's own chance of this, stated with the estimate: 70%; the middle value is on the limit's open side.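

In this assay compound 3 gives > 5000 nM, a limit of the assay and not a number. Compound 1 gives > 5000 nM, also a limit. Going by these compounds alone, no step from compound 1 to compound 3 can be read from these two limits. The compounds shown leave open whether 4-methylphenyl in place of 2-methoxyphenyl changes the value at all.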